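This account rests on a few compounds, and the source may have more. Where it says the series, first, only, none or still open, it means among the compounds named here.

Compound 3 `Cc1nc(-c2ccccc2)sc1C(=O)CSc1nc(-c2ccc(Cl)cc2)c(C#N)c(=O)[nH]1` gives 63.4% in a functional assay on U-87MG ATCC cells for antiproliferative activity against U-87 MG (Homo sapiens), read by MTT assay, with a stated time of 48 h, tested at 50 uM (a higher number here means a weaker effect of the compound at the concentration tested, a lower number a stronger effect), the highest of the three numbers measured. Compound 1 `Cc1nc(-c2ccc(Cl)cc2)sc1C(=O)CSc1nc(-c2ccccc2)c(C#N)c(=O)[nH]1` gives 41.6% and compound 2 `COc1ccc(-c2nc(SCC(=O)c3sc(-c4ccc(Cl)cc4)nc3C)[nH]c(=O)c2C#N)cc1` gives 46.3%; both lie beyond the scatter below compound 3. For the measured compounds named here, the one single-point step known, a number 4.7 percentage points higher from compound 1 to compound 2 (within the scatter), stays within the scatter. Compound 4 `Cc1nc(-c2ccc(Cl)cc2)sc1C(=O)CSc1nc(-c2ccc(Cl)cc2)c(C#N)c(=O)[nH]1` differs from compound 3 by chloro in place of hydrogen on an aromatic carbon. Going by the values given here, no measured step carries this same change, and the one known step concerns a methoxy rather than a chloro, so it gives little guidance. Compound 1 and compound 3 differ in two places, and their values alone show that the two patterns of chloro placement give different numbers. The estimate for compound 4 is 52%, within 36% to 68%, an expected step of a number 11.4 percentage points lower from compound 3 to compound 4 (beyond the scatter) whose direction is uncertain.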

Compound 4, a percentage reported as activity, at one concentration (the size of the read-out at that concentration, not a potency): 60%
Compound 4: middle estimate off by 8 percentage points, on the low side; measured number inside the range.
By their numbers in this assay, from the lowest: compounds 1 and 2 (each within the scatter of the next); then compounds 4 and 3 (each within the scatter of the next).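

In this assay, phenyl to 4-chlorophenyl at this position gives a number 3.4 percentage points lower from compound 3 to compound 4 (within the scatter), so chloro and hydrogen cannot be told apart here. On the other phenyl the substituent does register: chloro in place of hydrogen gives a number 18.4 percentage points higher from compound 1 to compound 4 (beyond the scatter) and chloro in place of methoxy gives a number 13.7 percentage points higher from compound 2 to compound 4 (beyond the scatter), which sets chloro there apart from both groups. No measured data on these compounds explain either result. Open, going by these compounds, is how an amine or a carboxylic acid would read on either phenyl in this assay.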